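A Third Methoxy Group and Cytotoxic Potency

The compounds below may be only part of what the source reports. "The series", "measured", "known", "first", "only" and "open" are said of these compounds alone.

Three compounds were tested in a functional assay on HeLa cells (Homo sapiens) for cytotoxicity, read by MTT assay, with a stated time of 72 h; on this read-out lower numbers stand for stronger inhibition and higher numbers for weaker inhibition. Compound 1 `COc1ccc(C(=O)/C=C/c2cc(OC)c(OC)c(OC)c2)c(F)c1` gives 144 nM. Compound 2 `COc1ccc(C(=O)/C=C/c2ccc(OC)cc2OC)c(F)c1` gives 260 nM in this assay, and compound 3 `COc1cc(/C=C/C(=O)c2ccc(OC)cc2F)cc(OC)c1` gives 243 nM. Compound 2 and compound 3 hold the same atoms joined differently; the difference between the two cores is not broken down here. Compound 1 arises from compound 3 by methoxy in place of hydrogen on an aromatic carbon, which gave a 1.7-fold lower number from compound 3 to compound 1 (0.23 log units; within the scatter). Compound 4 `COc1ccc(C(=O)/C=C/c2c(OC)cc(OC)cc2OC)c(F)c1` arises from compound 2 by the same kind of change, (methoxy in place of hydrogen on an aromatic carbon), though the surroundings differ: in compound 4 the group sits ortho to a large group and meta to two methoxy groups, while in compound 1 it sits ortho to two methoxy groups and para to a large group. Because the earlier step was a 1.7-fold lower number from compound 3 to compound 1 (0.23 log units; within the scatter), a similarly small step is expected, a 1.4-fold lower number from compound 2 to compound 4 (0.14 log units; within the scatter) in this assay. Compound 4 is therefore estimated at 190 nM, between 90 nM and 450 nM.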

Compound 4, half-maximal inhibitory concentration: > 100000 nM
Compound 4 ended at the assay's limit (the forecaster's own chance of this, stated with the estimate: 3%); middle value at least 520-fold (2.72 log units) away from the limit.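

Methoxy in place of hydrogen on an aromatic carbon gave an at least 380-fold higher number from compound 2 to compound 4 (2.58 log units; beyond the scatter) in this assay. Compound 4 gives > 100000 nM, which is a limit of the assay and not a number. The same change therefore does not carry over in size from one core to the other, although a comparison of only two cores cannot show which difference between them decides the outcome or why: the same change on two cores in this assay, a 1.7-fold lower number (0.23 log units; within the scatter) from compound 3 to compound 1 and an at least 380-fold higher number (2.58 log units; beyond the scatter) from compound 2 to compound 4, at least 640-fold (2.81 log units) apart, beyond the scatter of two such steps

As far as these compounds go, whether a hydroxyl or an ethoxy group in place of the added methoxy of compound 4 would give a number within the assay's range remains open. From the compounds shown here alone, it is also open whether a step this large would recur on any other core.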